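This account rests on a few compounds, and the source may have more. Where it says the series, first, only, none or still open, it means among the compounds named here.

Measured compounds:

- compound 1 `Oc1cccc(-c2cc(-c3ccc(Cl)cc3)nc(-c3cccs3)c2)c1`: 9280 nM
- compound 2 `Oc1cccc(-c2cc(-c3ccc(Cl)cc3)nc(-c3cccnc3)c2)c1`: 16800 nM
- compound 3 `Oc1ccc(-c2cc(-c3ccc(Cl)cc3)nc(-c3ccsc3)c2)cc1`: 6240 nM

All three share one core, to which a 4-chlorophenyl group, a hydroxyphenyl group and a third aromatic ring are attached. In a functional assay on HCT-15 cells (Homo sapiens) for cytotoxicity, read by CCK-8 assay and cell counting, with a stated time of 2 days (on this read-out lower numbers stand for stronger inhibition and higher numbers for weaker inhibition), compound 3 gives the lowest of the three numbers. Its nearest neighbour is compound 1, whose value lies within the scatter of it, so no order between these two can be claimed. Compound 2 lies beyond the scatter above compound 3.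

Compound 4 `Oc1cccc(-c2cc(-c3ccc(Cl)cc3)nc(-c3ccsc3)c2)c1` has not been measured. It differs from compound 3 in one place: 3-hydroxyphenyl in place of 4-hydroxyphenyl on an aromatic carbon. Among the compounds with values here, no measured pair isolates this change. Within the data shown here, the one measured step, a 1.8-fold higher number from compound 1 to compound 2 (0.26 log units; within the scatter), concerns the third aromatic ring, not the hydroxyphenyl group, and does not bear on the move from compound 3 to compound 4. Compound 1 and compound 3 differ in two places at once, so their values show only that two different arrangements sit close together within the scatter.

Without a measured step for this change, the expectation is a step from compound 3 to compound 4 of a 1.2-fold higher number from compound 3 to compound 4 (0.08 log units; within the scatter), none beyond the scatter. Compound 4 is therefore estimated at 7500 nM in this assay, with a range from 3000 nM to 18000 nM.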

Compound 4, half-maximal inhibitory concentration: 8850 nM
For compound 4 the middle estimate is 1.2-fold (0.07 log units) below the measured one, within the range that was stated.
By their numbers in this assay, from the lowest: compounds 3, 4, 1 and 2 (each within the scatter of the next, the first and the last beyond it).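

In this assay, moving the hydroxyl by putting 3-hydroxyphenyl in place of 4-hydroxyphenyl, on the carbon opposite the ring nitrogen, gives a 1.4-fold higher number from compound 3 to compound 4 (0.15 log units; within the scatter), so this position accepts either arrangement without a difference that can be claimed. With the 3-hydroxyphenyl group held fixed, the third aromatic ring can now be read in two further single changes: thiophen-3-yl in place of pyridin-3-yl gives a 1.9-fold lower number from compound 2 to compound 4 (0.28 log units; within the scatter), and thiophen-3-yl in place of thiophen-2-yl gives a 1.0-fold lower number from compound 1 to compound 4 (0.02 log units; within the scatter), so neither swap separates the compounds in this assay. Nothing measured here accounts for how closely these values sit together.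

All the compounds shown carry a hydroxyl on the phenyl group, so whether it matters at all stays open; a methoxy group, an amine or a carboxylic acid in its place would test that. On these data alone, the 4-chlorophenyl group is also the same throughout, and how a fluorine or a longer alkyl chain in place of its chlorine would read in this cell assay remains unknown.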